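The source may report more compounds than this note shows. Statements on the series, on what has been measured and on what is new or still open speak of the compounds shown alone.

Compound 1 `CN1CCN(c2ccc(Nc3ncc4nc(SCc5ccccc5)n(C5CCOCC5)c4n3)cc2)CC1`: 107 nM
Compound 2 `CN1CCN(c2ccc(Nc3ncc4nc([S+]([O-])c5ccccc5)n([C@H]5CC[C@H](O)CC5)c4n3)cc2)CC1`: 268 nM

In a functional assay on HCC827 cells (Homo sapiens) for antiproliferative activity, read by MTT assay, with a stated time of 72 h (a higher number here means a weaker inhibitor, a lower number a stronger inhibitor), compound 1 gives 107 nM, the lowest of the two numbers shown, and compound 2 gives 268 nM, a gap beyond the usual scatter. Compound 3 `CN1CCN(c2ccc(Nc3ncc4nc(Sc5ccccc5)n(C5CCOCC5)c4n3)cc2)CC1` is not yet measured; it differs from compound 1 in one place: phenyl in place of benzyl on a sulfur. Within the data shown here, no pair of measured compounds shows this change, so the size of the step is open. The step expected in this assay, a 1.4-fold higher number from compound 1 to compound 3 (0.15 log units; within the scatter), is small, likely within the scatter. Compound 3 is therefore estimated at about 150 nM, within a range from 60 nM to 400 nM.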

Compound 3, half-maximal inhibitory concentration: 42.6 nM
Compound 3: the middle estimate sits 3.5-fold (0.55 log units) above what was measured; the measured number lies below the stated range.
By their numbers in this assay, from the lowest: compound 3; then compound 1; then compound 2.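

Moving from benzyl to phenyl on this sulfur removes one carbon and gives a 2.5-fold lower number from compound 1 to compound 3 (0.40 log units; beyond the scatter) in this assay. This position therefore responds to a change as small as one carbon, and phenyl is the better of these two groups here. No measurement shown explains this gain.

Going by these compounds, whether a still longer chain, such as phenethyl, would raise the number further remains open. So does whether a fluorine or a methoxy group on the phenyl ring would lower it further.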